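Mirror image of a hydroxylated piperidine amide

This account rests on a few compounds, and the source may have more. Where it says the series, first, only, none or still open, it means among the compounds named here.

Compound 1 `O=C(Nc1ccc(Cl)cc1)C(=O)N1CCC(c2ccnc3ccc(F)cc23)CC1`: 6900 nM
Compound 2 `O=C(Nc1ccc(Cl)cc1)C(=O)N1CC[C@H](c2ccnc3ccc(F)cc23)[C@@H](O)C1`: 14000 nM

In an assay on HEK cells for inhibition of Tryptophan 2,3-dioxygenase (Homo sapiens) (on this read-out lower numbers stand for stronger inhibition and higher numbers for weaker inhibition), compound 2 gives the highest of the two numbers, with compound 1 next at a 2.0-fold higher number from compound 1 to compound 2 (0.31 log units; beyond the scatter). Compound 3 `O=C(Nc1ccc(Cl)cc1)C(=O)N1CC[C@@H](c2ccnc3ccc(F)cc23)[C@H](O)C1` differs from compound 2 as follows: the two compounds have the same atoms and bonds and differ only in configuration as drawn: 2 of 2 stereo elements differ (all stereocentres are inverted: mirror images); a stereocentre at a saturated ring carbon is drawn R in compound 2 and S in compound 3; a stereocentre at a saturated ring carbon is drawn R in compound 2 and S in compound 3. Among the compounds with values here, no measured step concerns an inversion of configuration, so the direction of the step in this assay cannot be read from compound 1 or compound 2; either enantiomer may carry more of the activity. Compound 3 is therefore expected near 7000 nM, within 1500 nM to 40000 nM, a step of a 2.0-fold lower number from compound 2 to compound 3 (0.30 log units; within the scatter) that is an estimate only.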

Compound 3, half-maximal inhibitory concentration: 15300 nM
Estimate against measurement, compound 3: 2.2-fold (0.34 log units) below; the measured number falls inside the stated range.
By their numbers in this assay, from the lowest: compound 1; then compounds 2 and 3 (each within the scatter of the next).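

In this assay, inverting both stereocentres gives a 1.1-fold higher number from compound 2 to compound 3 (0.04 log units; within the scatter), so the two mirror images cannot be told apart at this position. That reading concerns configuration alone, because nothing else separates the pair: the fact that compounds 2 and 3 differ only in the configuration as drawn Hydroxy in place of hydrogen on the saturated ring carbon also gives a modest step for both mirror images, with a 2.2-fold higher number from compound 1 to compound 3 (0.35 log units; beyond the scatter) alongside a 2.0-fold higher number from compound 1 to compound 2 (0.31 log units; beyond the scatter).

Still open, as far as these compounds go, is whether an amine or a methoxy group on that carbon would behave as hydroxy does. The compounds shown also leave open whether inverting only one of the two stereocentres would matter.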